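Changing one group on a carbonyl carbon

A few compounds are considered here, and "the series" means these few. Any claim that something is new, unique, unknown or untested is made for them only; others in the source may bear on it.

Three compounds that share a core and differ only in the group on a carbonyl carbon have been measured in a physicochemical assay for solubility (on this read-out higher numbers stand for higher solubility and lower numbers for lower solubility), so far. Compound 1 `O=C(c1ccc(C(F)(F)F)cc1)N1CCC(NS(=O)(=O)c2cc(S(=O)(=O)c3ccccc3)ccc2C(F)(F)F)CC1` gives 6300 nM on this scale and compound 2 `O=C(c1ccccn1)N1CCC(NS(=O)(=O)c2cc(S(=O)(=O)c3ccccc3)ccc2C(F)(F)F)CC1` gives 100000 nM as the highest number of the set. Compound 3 `CC(C)(C)OC(=O)N1CC[C@@H](C(=O)N2CCC(NS(=O)(=O)c3cc(S(=O)(=O)c4ccccc4)ccc3C(F)(F)F)CC2)C1` stands at 12500 nM in the lower part of the set, level with compound 1 once the usual scatter is allowed for.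

Compound 4 `O=C(C1CCNCC1)N1CCC(NS(=O)(=O)c2cc(S(=O)(=O)c3ccccc3)ccc2C(F)(F)F)CC1` has not been measured. It differs from compound 3 at that same carbonyl carbon, where piperidin-4-yl replaces 1-(tert-butoxycarbonyl)pyrrolidin-3-yl: piperidin-4-yl in place of 1-(tert-butoxycarbonyl)pyrrolidin-3-yl on a carbonyl carbon (the counted difference).

Among the compounds with values here, three measured steps bear on this change, all at this place. The first is a 16-fold higher number from compound 1 to compound 2 (1.20 log units; beyond the scatter) and counts as large, the second is an 8.0-fold lower number from compound 2 to compound 3 (0.90 log units; beyond the scatter) and counts as modest, and the third is a 2.0-fold higher number from compound 1 to compound 3 (0.30 log units; within the scatter) and shows no real change. So a swap here can move the number a long way or hardly at all. No measured compound carries piperidin-4-yl, which leaves the direction uncertain, but a rise is the more likely outcome given the room shown by compound 2 at 100000 nM on the same scale. The expected move is a 3.6-fold higher number from compound 3 to compound 4 (0.56 log units; beyond the scatter) by this estimate, a step of modest size. In this assay compound 4 is estimated at 45000 nM (expected range 15000 nM to 100000 nM).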

Compound 4, solubility: 100000 nM
For compound 4 the middle estimate is 2.2-fold (0.35 log units) below the measured one, and the stated range covers the measured number.
By their numbers in this assay, from the lowest: compounds 1 and 3 (each within the scatter of the next); then compounds 2 and 4 (each within the scatter of the next).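

Piperidin-4-yl on this carbonyl carbon gives an 8.0-fold higher number from compound 3 to compound 4 (0.90 log units; beyond the scatter) in this assay and a 16-fold higher number from compound 1 to compound 4 (1.20 log units; beyond the scatter) on the same scale. Set against pyridin-2-yl it shows no change at the digits printed from compound 2 to compound 4 (within the scatter) and so a non-aromatic ring now stands level with compound 2, which means that pyridin-2-yl is no longer the only group at the top of this small set. No measurement shown here gives a cause for these steps.

The step from compound 3 to compound 4 changes several things at once: the ring size, the tert-butoxycarbonyl group and the hydrogen-bond donor count all differ, and the compounds shown cannot separate these changes. From the compounds shown here alone, how pyrrolidin-3-yl without its tert-butoxycarbonyl group, 1-methylpiperidin-4-yl or a group carrying a carboxylic acid would read at this place remains open.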